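Swapping chloro for bromo on compound 3

The source may report more compounds than this note shows. Statements on the series, on what has been measured and on what is new or still open speak of the compounds shown alone.

Measured in a functional assay on A-375 cells (Homo sapiens) for antiproliferative activity, read by MTT assay, with a stated time of 24 h; a lower number here means a stronger inhibitor, a higher number a weaker inhibitor:
compound 1 `COc1cc(OC)c(-c2coc3cc(OCc4ccc([N+](=O)[O-])cc4)ccc3c2=O)cc1OC`: > 10000 nM (a limit of the assay, not a number)
compound 2 `COc1cc(OC)c(-c2coc3cc(OCc4ccc(C#N)cc4)ccc3c2=O)cc1OC`: 1550 nM
compound 3 `COc1cc(OC)c(-c2coc3cc(OCc4cccc(Cl)c4)ccc3c2=O)cc1OC`: 980 nM

Among the compounds with values here, only two of these three compounds give real numbers, and a 1.6-fold lower number from compound 2 to compound 3 (0.20 log units; within the scatter) stays within the scatter, so compound 3 cannot be ranked apart from its nearest neighbour. Two larger steps lead away from the limit: an at least 6.4-fold lower number from compound 1 to compound 2 (0.80 log units; beyond the scatter) and an at least 10-fold lower number from compound 1 to compound 3 (1.00 log units; beyond the scatter), both beyond the scatter.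

Compound 4 `COc1cc(OC)c(-c2coc3cc(OCc4cccc(Br)c4)ccc3c2=O)cc1OC` differs from compound 3 in one substituent: bromo in place of chloro on an aromatic carbon. It carries bromo in place of chloro on an aromatic carbon, meta to a large group. Within the data shown here, no measured step makes this exact swap. The large steps both start from the nitro group of compound 1, which is not involved here. The closer guide is the replacement of 4-cyanophenyl by 3-chlorophenyl, which moved the number only within the scatter, as a 1.6-fold lower number from compound 2 to compound 3 (0.20 log units; within the scatter) shows. The change to compound 4 is milder still, so no step beyond the scatter is expected in this assay.

The expected step is a 1.0-fold higher number from compound 3 to compound 4 (0.01 log units; within the scatter). For compound 4 the estimated value is 1000 nM, with an expected range of 400 nM to 2500 nM.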

Compound 4, half-maximal inhibitory concentration: 1120 nM
Estimate against measurement, compound 4: 1.1-fold (0.05 log units) below; the measured number falls inside the stated range.
By their numbers in this assay, from the lowest: compounds 3, 4 and 2 (each within the scatter of the next). At a limit, above all of these: compound 1.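

In this assay, bromo in place of chloro on an aromatic carbon, meta to a large group, gives a 1.1-fold higher number from compound 3 to compound 4 (0.06 log units; within the scatter), so this assay cannot tell these two halogens apart at this position. Comparing compound 4 with the other two compounds shows the same split as compound 3 did: 3-bromophenyl in place of 4-cyanophenyl gives a 1.4-fold lower number from compound 2 to compound 4 (0.14 log units; within the scatter), while 3-bromophenyl in place of 4-nitrophenyl gives an at least 8.9-fold lower number from compound 1 to compound 4 (0.95 log units; beyond the scatter). Compound 1 stands at a limit of the assay and not at a real number, so that last step has no exact size: the limit of > 10000 nM in this assay, at which 1 of the 4 values shown sits.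

On these data alone, what a group of a different kind, such as an amine or a carboxylic acid, would do on this aromatic carbon remains open. Also open is whether chloro and bromo would stay this close on another carbon of the same ring, as the compounds shown offer no 4-chlorophenyl or 4-bromophenyl partner for compound 3 or compound 4.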